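This account rests on a few compounds, and the source may have more. Where it says the series, first, only, none or still open, it means among the compounds named here.

Measured so far, in an assay on isolated protein for inhibition of matrix metalloproteinase-9 (Homo sapiens), read by fluorescence, with stated times of 3 h, 10 s and 15 min; on this read-out lower numbers stand for stronger inhibition and higher numbers for weaker inhibition:
compound 1, `CO[C@@H]1O[C@H](CNC(=S)NCCN([C@@H](C(=O)O)C(C)C)S(=O)(=O)c2ccc(-c3ccccc3)cc2)[C@@H](O)[C@H](O)[C@H]1O`, gives 520 nM;
compound 2, `CC(=O)N[C@@H]1[C@@H](O)[C@H](O)[C@@H](CO)O[C@H]1NC(=S)NCCN([C@@H](C(=O)O)C(C)C)S(=O)(=O)c1ccc(-c2ccccc2)cc1`, gives 5400 nM.

Going by the values given here, of these two numbers, compound 2 has the higher one, and so is the weaker inhibitor of the pair; the only other measured compound, compound 1, sits at a lower number by a gap that is beyond the usual scatter of repeated measurements. Compound 3, `CC(C)[C@H](C(=O)O)N(CCNC(=S)N[C@@H]1O[C@H](CO)[C@@H](O)[C@H](O)[C@H]1O)S(=O)(=O)c1ccc(-c2ccccc2)cc1`, has not yet been measured. It differs from compound 2 in one place: hydroxy in place of acetamido on a saturated ring carbon, that is, a hydroxy in place of acetamido on a saturated ring carbon. Among the compounds with values here, no measured pair shows this exact change, and compound 1 carries a differently built sugar part, so its value cannot be read as a guide to the size of this step. For compound 3 in this assay a step of modest size is expected, leaning toward a lower number, namely a 1.8-fold lower number from compound 2 to compound 3 (0.26 log units; within the scatter). Compound 3 is accordingly estimated at 3000 nM, within a range from 1000 nM to 9000 nM.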

Compound 3, half-maximal inhibitory concentration: 1120 nM
Estimate against measurement, compound 3: 2.7-fold (0.43 log units) above; the measured number falls inside the stated range.
By their numbers in this assay, from the lowest: compound 1; then compound 3; then compound 2.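

In this assay, the acetamido group on this saturated ring carbon is not needed for inhibition: putting a hydroxy in its place gives a 4.8-fold lower number from compound 2 to compound 3 (0.68 log units; beyond the scatter), so this single exchange on the ring makes a clear difference. Replacing the whole group of 12 heavy atoms on the amide-type nitrogen with a group of 11 heavy atoms also moves the number, giving a 2.2-fold higher number from compound 1 to compound 3 (0.33 log units; beyond the scatter), which leaves compound 1 as the strongest inhibitor of the three and shows that removing the acetamido group does not by itself reach the best value seen here. Nothing shown explains why either change has this effect.

Still open, from the compounds shown here alone, is whether hydroxy is the best group at this ring carbon, since an amine, a methoxy group or a longer amide such as propionamido could give a lower or a higher number. Going by these compounds, it is also open whether acetamido would cost as much on the ring part of compound 1 as it does on the ring part of compound 3.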